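A Methoxy Group on the Anilino Ring of Compound 1

The source may hold more compounds than are shown below. What is called first, only, known or untested is meant among the compounds shown, and "the series" means these compounds.

Compound 1, `Cc1nc(SCC(=O)Nc2nc(-c3ccc(Cl)cc3)cs2)n(Nc2ccccc2)c1C`: 10100 nM
Compound 2, `Cc1ccc(Nn2c(SCC(=O)Nc3nc(-c4ccccc4)cs3)nc(C)c2C)cc1`: 14200 nM

In a functional assay on SN12C cells (Homo sapiens) for antiproliferative activity, read by sulforhodamine B assay, with a stated time of 48 h (a lower number here means a stronger inhibitor of growth, a higher number a weaker inhibitor of growth), compound 1 holds the lowest of the two numbers, yet compound 2 lies within the scatter of it, so the two cannot be ordered. Compound 3, `COc1ccc(Nn2c(SCC(=O)Nc3nc(-c4ccc(Cl)cc4)cs3)nc(C)c2C)cc1`, differs from compound 1 by methoxy in place of hydrogen on an aromatic carbon. Within the data shown here, no measured pair isolates this change; compound 2 differs from compound 1 at two places at once, so only its value can be noted. In this assay the step of a 1.0-fold lower number from compound 1 to compound 3 (0.00 log units; within the scatter) is expected to stay within the scatter. Compound 3 is therefore estimated at 10000 nM, between 4000 nM and 25000 nM.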

Compound 3, concentration for total growth inhibition: 7520 nM
Beside the measured number, compound 3's estimate is 1.3-fold (0.12 log units) above it; low and high end bracket the measured number.
By their numbers in this assay, from the lowest: compounds 3, 1 and 2 (each within the scatter of the next).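

In this assay, the anilino to (4-methoxyphenyl)amino change gives a 1.3-fold lower number from compound 1 to compound 3 (0.13 log units; within the scatter), the only step shown that isolates a change on this ring. Methoxy in place of hydrogen on this aromatic carbon, para to a large group, is therefore accommodated with no difference that can be told from the scatter. No available evidence bears on this result. The compounds shown leave open whether an amine or a carboxylic acid on this same carbon would move the number beyond the scatter.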